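This account rests on a few compounds, and the source may have more. Where it says the series, first, only, none or still open, it means among the compounds named here.

Compounds measured in an in vitro assay on SH-SY5Y cells for displacement of a labelled ligand from Neuronal acetylcholine receptor; alpha3/beta4 (Homo sapiens); on this read-out lower numbers stand for stronger inhibition and higher numbers for weaker inhibition:
compound 1, `C1=C(c2cncc(OCc3ccccc3)c2)CC2CNCC1C2` — 44 nM
compound 2, `C1=C(c2cccnc2)C[C@H]2CNC[C@@H]1C2` — 4 nM
compound 3, `C1=C(c2ccc(-c3ccccc3)nc2)CC2CNCC1C2` — 507 nM

Compound 1 stands second highest of the three numbers, a step beyond the scatter from compound 2 and a step beyond the scatter from compound 3. Compound 4 is `CC(C)Oc1cncc(C2=CC3CNCC(C2)C3)c1`, not yet measured in this assay. Compound 4 differs from compound 1 in one place: isopropyl in place of benzyl on an oxygen on an aromatic ring. Going by the values given here, no measured pair shows this change, so the expected size of the step rests on the three numbers alone: a modest step toward a lower number is expected, a 1.8-fold lower number from compound 1 to compound 4 (0.25 log units; within the scatter), possibly within the scatter. Compound 4 is estimated at 25 nM, within a range from 8 nM to 80 nM.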

Compound 4, inhibition constant: 4.8 nM
Compound 4: the middle estimate sits 5.2-fold (0.72 log units) above what was measured; measured number below the stated range.
By their numbers in this assay, from the lowest: compounds 2 and 4 (each within the scatter of the next); then compound 1; then compound 3.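

In this assay, the group on this oxygen proves to matter: isopropyl in place of benzyl gives a 9.2-fold lower number from compound 1 to compound 4 (0.96 log units; beyond the scatter) and the step is beyond the scatter. Going by these compounds alone, the earlier compounds held no pair that differed only here, so this is the first reading of the position, and it shows that the benzyl ring is not needed for a low number. No measurement shown explains the size of this step.

The compounds shown leave open how methyl or a longer chain such as n-butyl would read on this oxygen. Also open, from the compounds shown here alone, is whether an amine in place of the oxygen would keep the low number.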